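Thiophen-3-yl for thiophen-2-yl: a weak cytotoxicity series

The source may report more compounds than this note shows. Statements on the series, on what has been measured and on what is new or still open speak of the compounds shown alone.

For the measured compounds named here, compound 3 `CSc1ncnc2c1c(-c1cccs1)cn2[C@@H]1O[C@H](CO)[C@@H](O)[C@H]1O` is the only compound here with a number in an ADME assay on BJ cells (Homo sapiens), read by MTT assay, with a stated time of 72 h; on this read-out lower numbers stand for stronger inhibition and higher numbers for weaker inhibition: compound 3 gives 96900 nM. Compound 1 `CSc1ncnc2c1c(-c1ccccc1)cn2[C@@H]1O[C@H](CO)[C@@H](O)[C@H]1O` reaches only a limit of the assay in this assay, where compound 1 gives > 100000 nM. Compound 2 `CNc1ncnc2c1c(-c1ccsc1)cn2[C@@H]1O[C@H](CO)[C@@H](O)[C@H]1O` likewise reaches only a limit, as in this assay compound 2 gives > 100000 nM. Going by the values given here, the one measured step, an at least 1.0-fold lower number from compound 1 to compound 3 (0.01 log units; that floor lies within the scatter), lies within the scatter, and sits against (the limit of > 100000 nM in this assay, at which 2 of the 3 values shown sit).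

Compound 4 `CSc1ncnc2c1c(-c1ccsc1)cn2[C@@H]1O[C@H](CO)[C@@H](O)[C@H]1O` is not yet measured. It differs from compound 3 by thiophen-3-yl in place of thiophen-2-yl on an aromatic carbon. Among the compounds with values here, no measured step covers this exact exchange. Compound 2 also carries thiophen-3-yl, but it differs from compound 4 in another place as well, so its limit only shows that a thiophen-3-yl compound can sit at the assay limit. Given that every value shown is at or near (the limit of > 100000 nM in this assay, at which 2 of the 3 values shown sit), compound 4 is expected to change little, and the estimated step of a 1.0-fold higher number from compound 3 to compound 4 (0.01 log units; within the scatter) is expected to stay within the scatter. Compound 4 is therefore estimated at 100000 nM, within 50000 nM to 200000 nM.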

Compound 4, half-maximal inhibitory concentration: 95800 nM
The estimate for compound 4 lay 1.0-fold (0.02 log units) above the measured number; measured number inside the range.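

Thiophen-3-yl in place of thiophen-2-yl on an aromatic carbon of the shared core now has a direct measurement: in this assay, the exchange gives a 1.0-fold lower number from compound 3 to compound 4 (0.00 log units; within the scatter). At this place on the five-membered aromatic ring, the two thiophene attachments therefore cannot be told apart in this read-out, at least with the methylsulfanyl group present in both compound 3 and compound 4. Thiophen-3-yl in place of phenyl on an aromatic carbon gives an at least 1.0-fold lower number from compound 1 to compound 4 (0.01 log units; that floor lies within the scatter), and methylsulfanyl in place of methylamino on an aromatic carbon gives an at least 1.0-fold lower number from compound 2 to compound 4 (0.01 log units; that floor lies within the scatter). Neither of these two steps can be read as a size, because each starts from a limit of the assay rather than a number: the limit of > 100000 nM in this assay, at which 2 of the 4 values shown sit.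

The compounds shown carry only phenyl and the two thiophene groups at this place, so their similar readings say little about very different groups. As far as these compounds go, whether furan-2-yl, pyridin-3-yl or a chain ending in an amine would give a clearly lower number remains open.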